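The source may hold more compounds than are shown below. What is called first, only, known or untested is meant among the compounds shown, and "the series" means these compounds.

Measured compounds:
- compound 1 `Brc1cn2ccnc2c(-c2ccc3ncn(C4CCCCC4)c3c2)n1`
- compound 2 `O=Cc1ccc(-c2cn3ccnc3c(-c3ccc4ncn(C5CCCCC5)c4c3)n2)cc1`
- compound 3 `c1cn2cc(-c3ccsc3)nc(-c3ccc4ncn(C5CCCCC5)c4c3)c2n1`

All three share one core and differ only in the group attached to it. In a functional assay on SK-MEL-5 cells (Homo sapiens) for inhibition, read by sulforhodamine B assay, with a stated time of 48 h, tested at 10 uM (on this read-out higher numbers stand for more inhibition at the one concentration tested (going by the name of the read-out) and lower numbers for less inhibition), compound 1 gives 13.4%, compound 2 gives 56.5% and compound 3 gives 25%. Compound 2 stands highest of the three, with both steps to it beyond the scatter: a number 43.1 percentage points higher from compound 1 to compound 2 (beyond the scatter) and a number 31.5 percentage points lower from compound 2 to compound 3 (beyond the scatter). The smaller move a number 11.6 percentage points higher from compound 1 to compound 3 (beyond the scatter) is modest.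

Compound 4 `Brc1ccc(-c2cn3ccnc3c(-c3ccc4ncn(C5CCCCC5)c4c3)n2)cc1` keeps the phenyl ring of compound 2 but changes one substituent on it: bromo in place of formyl on an aromatic carbon. For the measured compounds named here, no measured step changes only that substituent, so nothing directly tells what the formyl group contributes. The two large steps show that the whole 4-formylphenyl group matters greatly in this assay, while compound 3 shows another ring in the same place is far weaker. Losing the formyl group alone is therefore expected to cost some inhibition, but the size is uncertain.

For compound 4 in this assay the expected step is a number 18.5 percentage points lower from compound 2 to compound 4 (beyond the scatter).

Compound 4 is estimated at 38%, within a range from 15% to 60%.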

Compound 4, a percentage reported as inhibition, at one concentration (the size of the read-out at that concentration, not a potency): 23.6%
The estimate for compound 4 lay 14.4 percentage points above the measured number; low and high end bracket the measured number.
By their numbers in this assay, from the lowest: compound 1; then compounds 4 and 3 (each within the scatter of the next); then compound 2.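

With only one substituent on the phenyl ring changed, the formyl group itself turns out to matter in this assay (with a number 32.9 percentage points lower from compound 2 to compound 4 (beyond the scatter)), so a phenyl ring at this position does not by itself give the level of compound 2. Carrying bromo, that ring does no better than the thiophen-3-yl group (with a number 1.4 percentage points lower from compound 3 to compound 4 (within the scatter)), and it offers only a modest gain over bromo alone on the core (with a number 10.2 percentage points higher from compound 1 to compound 4 (beyond the scatter)). Nothing in the data shown explains why exchanging formyl for bromo has this effect.

Still open, on these data alone, is whether another group in the place of formyl on the phenyl ring, such as a carboxylic acid, an amine or a nitrile, would match or exceed formyl. Also open, as far as these compounds go, is whether a formyl group on the thiophen-3-yl ring would bring a similar gain.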